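Swapping a Sulfonamide for a Nitro Group

A few compounds are considered here, and "the series" means these few. Any claim that something is new, unique, unknown or untested is made for them only; others in the source may bear on it.

Of the compounds shown here, two have been measured in an assay on COS-7 cells for inhibition of patatin-like phospholipase domain-containing protein 2 (Mus musculus), tested at 200 uM; on this read-out lower numbers stand for less inhibition and higher numbers for more inhibition at the one concentration tested (going by the name of the read-out). Compound 1 `CCOC(=O)c1cccc(-c2ccc(CN(C)C)cc2)c1` gives 67% in this assay. Compound 2 `CCNS(=O)(=O)c1cccc(-c2ccc(OCC)cc2)c1` gives 46% in this assay, the lower of the two numbers, sitting a gap beyond the usual scatter below compound 1. Compound 3 `CCOc1ccc(-c2cccc([N+](=O)[O-])c2)cc1` has not yet been measured. It differs from compound 2 in one place: nitro in place of ethylsulfamoyl on an aromatic carbon. Both groups that change carry hydrogen-bond acceptors, but the ethylsulfamoyl group that leaves brings a hydrogen-bond donor that the nitro group lacks. For the measured compounds named here, no measured pair shows what such a swap does, so the direction of the step is open; the step is expected to be a number 4 percentage points higher from compound 2 to compound 3 (within the scatter), meaning no change beyond the scatter. Compound 3 is estimated to give 50% in this assay, within a range from 25% to 75%.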

Compound 3, a percentage reported as inhibition, at one concentration (the size of the read-out at that concentration, not a potency): 35%
Compound 3: the middle estimate sits 15 percentage points above what was measured; the measured number falls inside the stated range.
By their numbers in this assay, from the lowest: compound 3; then compound 2; then compound 1.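

In this assay, for the compounds shown here, this is the only measured pair of compounds that differ in one place, and it shows that the group on this aromatic carbon, meta to a group of 9 heavy atoms, can change the result. Nitro in place of ethylsulfamoyl gives a number 11 percentage points lower from compound 2 to compound 3 (beyond the scatter), so this swap does not leave the number unchanged. The entering group has fewer heavy atoms and no hydrogen-bond donor, but nothing measured here explains the drop or separates these two differences.

As far as these compounds go, whether an amine, a carboxylic acid or a longer chain on this carbon would give a higher or lower number remains open. A simple sulfonamide with a methyl group in place of the ethyl group could show whether the chain on the nitrogen matters.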